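The source may hold more compounds than are shown below. What is called first, only, known or untested is meant among the compounds shown, and "the series" means these compounds.

Going by the values given here, compound 2 `CCC(CC)n1c(-c2ccc(OCc3c(-c4c(Cl)cccc4Cl)noc3C(C)C)cc2)nc2ccc(C(=O)O)cc21` gives 26.5 nM in an assay on isolated protein for agonist activity at Bile acid receptor (Homo sapiens), read by TR-FRET (on this read-out lower numbers stand for an effect already at smaller amounts and higher numbers for an effect only at larger amounts of compound), the lower of the two numbers measured so far. Among the compounds with values here, compound 1 `CCC(CC)n1c(-c2ccc(OCc3c(-c4c(Cl)cccc4Cl)noc3C(C)C)cc2F)nc2ccc(C(=O)O)cc21` gives 69.3 nM in this assay, and the only recorded step is a 2.6-fold lower number from compound 1 to compound 2 (0.42 log units; beyond the scatter). Compound 3 `CC(C)c1onc(-c2c(Cl)cccc2Cl)c1COc1ccc(-c2nc3ccc(C(=O)O)cc3n2Cc2ccc(F)cc2)cc1` differs from compound 2 by 4-fluorobenzyl in place of pentan-3-yl on an aromatic nitrogen. Within the data shown here, no measured step bears on this change: the one known step concerns a fluoro on an aromatic carbon, not the group on the ring nitrogen. For compound 3 a step of a 1.5-fold higher number from compound 2 to compound 3 (0.18 log units; within the scatter) is expected, no larger than the scatter. The estimate for compound 3 in this assay is 40 nM, between 10 nM and 160 nM.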

Compound 3, half-maximal effective concentration: 105 nM
Estimate against measurement, compound 3: 2.6-fold (0.42 log units) below; measured number inside the range.
By their numbers in this assay, from the lowest: compound 2; then compounds 1 and 3 (each within the scatter of the next).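

The group on the aromatic nitrogen does affect the read-out in this assay: 4-fluorobenzyl in place of pentan-3-yl gives a 4.0-fold higher number from compound 2 to compound 3 (0.60 log units; beyond the scatter). Going by these compounds alone, this is the first recorded step at this position, and it shows that a group carrying a six-membered aromatic ring is accepted there, though at a higher number than pentan-3-yl. Nothing measured here accounts for this step.

The compounds shown leave open whether the ring or the fluoro goes with the higher number. An unsubstituted benzyl or a cyclohexyl on the same nitrogen would help separate the two.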